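A few compounds are considered here, and "the series" means these few. Any claim that something is new, unique, unknown or untested is made for them only; others in the source may bear on it.

Measured compounds in an assay on U2OS cells for inhibition of secreted frizzled-related protein 1 (Homo sapiens), read by a luciferase reporter, with a stated time of 18 h; on this read-out higher numbers stand for an effect only at larger amounts of compound and lower numbers for an effect already at smaller amounts:
Compound 1, `O=C(c1cccc(Cl)c1)N1CCC(NS(=O)(=O)c2cc(S(=O)(=O)c3ccccc3)ccc2C(F)(F)F)CC1`: 870 nM
Compound 2, `O=C(c1cccnc1)N1CCC(NS(=O)(=O)c2cc(S(=O)(=O)c3ccccc3)ccc2C(F)(F)F)CC1`: 120 nM
Compound 3, `N#Cc1cccc(S(=O)(=O)N2CCC(NS(=O)(=O)c3cc(S(=O)(=O)c4ccccc4)ccc3C(F)(F)F)CC2)c1`: 170 nM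

Compound 2 shows the lowest number of the three, though its gap to compound 3 lies within the scatter, so these two stand level, while its gap to compound 1 lies beyond the scatter. Compound 4, `CC(C)(C)OC(=O)N1CC[C@@H](C(=O)N2CCC(NS(=O)(=O)c3cc(S(=O)(=O)c4ccccc4)ccc3C(F)(F)F)CC2)C1`, has not been measured. It differs from compound 2 in one place: 1-(tert-butoxycarbonyl)pyrrolidin-3-yl in place of pyridin-3-yl on a carbonyl carbon. Among the compounds with values here, two measured steps touch the same part of the molecule. The step of a 7.3-fold lower number from compound 1 to compound 2 (0.86 log units; beyond the scatter) shows that exchanging one six-membered aromatic ring for another on the carbonyl carbon can shift the number clearly, and the step of a 1.4-fold higher number from compound 2 to compound 3 (0.15 log units; within the scatter) shows that a further swap of the ring together with its linking group stays within the scatter. Neither step replaces the aromatic ring with a five-membered non-aromatic ring carrying a tert-butoxycarbonyl group, so the change to compound 4 goes beyond what has been tested. The expectation for compound 4 is therefore a modest rise in the number, a 2.9-fold higher number from compound 2 to compound 4 (0.46 log units; beyond the scatter), with wide uncertainty. Compound 4 is estimated at 350 nM, in the range 100 nM to 1500 nM.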

Compound 4, half-maximal effective concentration: 80 nM
The estimate for compound 4 lay 4.4-fold (0.64 log units) above the measured number; measured number outside the range, below it.
By their numbers in this assay, from the lowest: compounds 4, 2 and 3 (each within the scatter of the next, the first and the last beyond it); then compound 1.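

In this assay, this position on the carbonyl carbon turns out not to depend on an aromatic ring: the five-membered non-aromatic 1-(tert-butoxycarbonyl)pyrrolidin-3-yl group, with 12 heavy atoms where pyridin-3-yl has 6, replaces that ring with a 1.5-fold lower number from compound 2 to compound 4 (0.18 log units; within the scatter), so compound 2 and compound 4 stand level. The same new group in place of 3-chlorophenyl gives an 11-fold lower number from compound 1 to compound 4 (1.04 log units; beyond the scatter), the largest step among these compounds, and compound 1 alone stands apart from the other three, so an aromatic ring at this place neither guarantees nor rules out a low number. Nothing measured here accounts for why so different a group leaves the number level with that of compound 2.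

It remains open whether the tert-butoxycarbonyl group matters, since the compounds shown do not tell how the same pyrrolidine ring would read with a free amine or an acetyl group on its nitrogen. As far as these compounds go, how the mirror-image form of compound 4 would compare also stays open.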